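Swapping the amide substituent of compound 1 for an open chain

The compounds below may be only part of what the source reports. "The series", "measured", "known", "first", "only" and "open" are said of these compounds alone.

Measured compounds:
compound 1 `COc1cccc(OC)c1C(=O)Nc1c[nH]nc1C(=O)N[C@H]1CC[C@H](OC)CC1`: 31000 nM
compound 2 `CO[C@H]1CC[C@H](NC(=O)c2n[nH]cc2NC(=O)c2ccccc2F)CC1`: 1000 nM

In an ADME assay on MRC5 cells (Homo sapiens) for inhibition, with a stated time of 72 h (on this read-out higher numbers stand for an effect only at larger amounts of compound and lower numbers for an effect already at smaller amounts), compound 1 gives 31000 nM, the highest of the two numbers at hand. Going by the values given here, compound 2, the other measured compound, gives 1000 nM in this assay, a gap that lies beyond the usual scatter; the two compounds differ in more than one place, so the data allow no single step to be drawn between them.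

Compound 3 `COc1cccc(OC)c1C(=O)Nc1c[nH]nc1C(=O)NCCCN(C)C` has not been measured in this assay. It differs from compound 1 in one place: 3-(dimethylamino)propyl in place of 4-methoxycyclohexyl on an amide-type nitrogen

Among the compounds with values here, no measured pair follows this change, so the step can only be estimated. For compound 3 the step of a 1.6-fold lower number from compound 1 to compound 3 (0.19 log units; within the scatter) is expected to be small, toward a lower number, and close to the scatter. Compound 3 is therefore expected to give about 20000 nM in this assay, between 5000 nM and 60000 nM.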

Compound 3, half-maximal effective concentration: > 50000 nM
Compound 3: only a limit was reported; the forecaster's own chance of this, stated with the estimate: 30%; middle value at least 2.5-fold (0.39 log units) from the limit.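

In this assay, the open chain on the amide-type nitrogen gives an at least 1.6-fold higher number from compound 1 to compound 3 (0.20 log units; that floor lies within the scatter), and this step is only a floor, as the reading for compound 3 is a limit and not a number. On these data alone, the 3-(dimethylamino)propyl group therefore brings no move toward a lower number on the core of compound 1, though how far the true number lies past the limit stays unknown. Compound 3 is the only compound shown that ends at the limit: the limit of > 50000 nM in this assay, at which 1 of the 3 values shown sits.

As far as these compounds go, whether a plain cyclohexyl or a chain ending in a carboxylic acid on this nitrogen would move the number remains open. Also open, from the compounds shown here alone, is whether the same change would read alike on compound 2, which carries the 4-methoxycyclohexyl and gives 1000 nM.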